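Estimating a 3,5-difluorobenzyl swap in the cytotoxicity read-out

The source may report more compounds than this note shows. Statements on the series, on what has been measured and on what is new or still open speak of the compounds shown alone.

Compound 1 `CCOCn1c(Cc2cc(F)cc(F)c2)c(I)c(=O)[nH]c1=O`: 300000 nM
Compound 2 `O=c1[nH]c(=O)n(COCc2ccccc2)c(Cc2ccccc2)c1I`: 74800 nM
Compound 3 `Cc1cc(C)cc(Cc2c(I)c(=O)[nH]c(=O)n2COCc2ccccc2)c1`: 98300 nM

In an ADME assay on MT4 cells (Homo sapiens) for cytotoxicity, read by XTT assay, with a stated time of 3 days (on this read-out higher numbers stand for lower toxicity in this test and lower numbers for higher toxicity in this test), compound 3 gives 98300 nM. That number lies within the scatter of compound 2 and beyond the scatter of compound 1, which holds the highest number of the three. The next compound, compound 4 `O=c1[nH]c(=O)n(COCc2ccccc2)c(Cc2cc(F)cc(F)c2)c1I`, has not yet been measured. It differs from compound 3 by one change, 3,5-difluorophenyl in place of 3,5-dimethylphenyl on a saturated chain carbon bound to an aromatic carbon.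

Among the measured compounds shown here, one measured step bears directly on this place: a 1.3-fold higher number from compound 2 to compound 3 (0.12 log units; within the scatter). Putting 3,5-dimethylphenyl in place of phenyl there therefore left the number within the scatter. For the measured compounds named here, compound 1 also carries the 3,5-difluorobenzyl group and gives 300000 nM, but no measured step links it to the other compounds, so its number does not isolate this change. Going by the values given here, with only one such step to go on, no shift beyond the scatter is expected in this assay, and no direction can be favoured. The expected outcome is a 1.0-fold higher number from compound 3 to compound 4 (0.01 log units; within the scatter). For compound 4 the estimated value is 100000 nM, with an expected range from 45000 nM to 230000 nM.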

Compound 4, half-maximal cytotoxic concentration: 121000 nM
For compound 4 the middle estimate is 1.2-fold (0.08 log units) below the measured one; low and high end bracket the measured number.
By their numbers in this assay, from the lowest: compounds 2, 3 and 4 (each within the scatter of the next); then compound 1.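

In this assay, both a 1.2-fold higher number from compound 3 to compound 4 (0.09 log units; within the scatter) and a 1.6-fold higher number from compound 2 to compound 4 (0.21 log units; within the scatter) stay within the scatter, so the phenyl, 3,5-dimethylphenyl and 3,5-difluorophenyl groups on a saturated chain carbon bound to an aromatic carbon cannot be told apart in this test. Compound 4 also provides the first single-change link to compound 1, and a 2.5-fold lower number from compound 1 to compound 4 (0.39 log units; beyond the scatter) lies beyond the scatter: with the 3,5-difluorobenzyl group held constant, phenyl in place of methyl on a saturated chain carbon bound to an oxygen on a saturated carbon goes with a modest shift towards higher toxicity in this test. Among the compounds shown, the only step beyond the scatter is therefore at this second place, and nothing given here offers an explanation for either result.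

Among the compounds shown here, it remains open whether the phenyl-for-methyl step would be of similar size with the unsubstituted benzyl or 3,5-dimethylbenzyl group, since only one such pair can be read. From the compounds shown here alone, it is also open whether the number would stay within the scatter with an aromatic ring carrying an amine or a carboxylic acid, or with a longer chain in place of the benzyl group.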